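Fluorine position on the benzyl arm: compound 3 to compound 4

A few compounds are considered here, and "the series" means these few. Any claim that something is new, unique, unknown or untested is made for them only; others in the source may bear on it.

Among the compounds with values here, in a functional assay on MCF7 cells (Homo sapiens) for cytotoxicity, read by MTT assay, with a stated time of 72 h (a higher number here means a weaker inhibitor, a lower number a stronger inhibitor), compound 3 `O=C(NC1CCCCC1)N1CCN(C(=S)SCc2cn(Cc3ccccc3F)nn2)CC1` gives 85000 nM, the highest number among the three measured members. Compound 1 `CCN(C)C(=O)N1CCN(C(=S)SCc2cn(Cc3ccccc3F)nn2)CC1` gives 7210 nM, and compound 2 `CC(C)(C)NC(=O)N1CCN(C(=S)SCc2cn(Cc3ccccc3F)nn2)CC1` gives 18800 nM. The measured steps all change the urea end of the shared core: a 2.6-fold higher number from compound 1 to compound 2 (0.42 log units; beyond the scatter), a 12-fold higher number from compound 1 to compound 3 (1.07 log units; beyond the scatter), and a 4.5-fold higher number from compound 2 to compound 3 (0.66 log units; beyond the scatter). Compound 4 `O=C(NC1CCCCC1)N1CCN(C(=S)SCc2cn(Cc3ccc(F)cc3)nn2)CC1` keeps the cyclohexyl urea of compound 3 and differs only at the other end: 4-fluorophenyl in place of 2-fluorophenyl on a saturated chain carbon bound to an aromatic nitrogen. Within the data shown here, none of the three measured steps touches this benzyl arm; every measured compound carries the 2-fluorophenyl group, so the series holds no step that bears on moving the fluorine. The expectation therefore rests on compound 3 alone, and the working assumption is a step of no change at the digits printed from compound 3 to compound 4 (within the scatter), that is, none beyond the scatter, with a wide range to reflect the absence of any guide. Compound 4 is accordingly estimated at 85000 nM in this assay, within a range from 30000 nM to 250000 nM. Compound 3 gives 85000 nM, and the number expected for compound 4 stays near it.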

Compound 4, half-maximal inhibitory concentration: > 128000 nM
Compound 4 gave a limit, no number (the forecaster's own chance of this, stated with the estimate: 30%); middle value at least 1.5-fold (0.17 log units) away from the limit.
By their numbers in this assay, from the lowest: compound 1; then compound 2; then compound 3. At a limit, above all of these: compound 4.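

In this assay, within the data shown here, the only step that touches the benzyl arm is 4-fluorobenzyl in place of 2-fluorobenzyl on the cyclohexyl urea, and it reads as an at least 1.5-fold higher number from compound 3 to compound 4 (0.17 log units; that floor lies within the scatter). Compound 4 gives > 128000 nM, which is a limit and not a number. The step therefore has a floor but no size, and that floor does not separate compound 4 from compound 3 beyond the scatter, although the move shows no lower number on this urea, and this is the one limit in the series: the limit of > 128000 nM in this assay, at which 1 of the 4 values shown sits.

The fluorine move is shown only on the cyclohexyl urea, so its effect on the number stays open for the ethyl(methyl)amino urea of compound 1 and the tert-butylamino urea of compound 2, where the starting values lie further from the limit. Also open, on these data alone, is how the arm reads with no fluorine at all, as plain benzyl, or with chlorine or a methoxy group on the phenyl ring in place of fluorine.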